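This account rests on a few compounds, and the source may have more. Where it says the series, first, only, none or still open, it means among the compounds named here.

Measured so far:
Compound 1, `O=c1cccnn1CCC(=S)N1CCCC1`: 29.7%
Compound 2, `NC(=O)CCn1nc(-c2ccccc2)ccc1=O`: -2.8%
Compound 3, `CC(Cn1nc(-c2ccccc2)ccc1=O)C(=N)S`: 86.4%

In a functional assay on the whole organism (stomach) for inhibition, with Rattus norvegicus as the target, at a dose of 100 mg/kg by the intraduodenal route (on this read-out higher numbers stand for more inhibition at the one dose given (going by the name of the read-out) and lower numbers for less inhibition), compound 2 gives the lowest of the three numbers, -2.8%. Its nearest neighbour is compound 1, and the furthest is compound 3, which sits far above it, beyond the scatter.

Compound 4, `O=c1ccc(-c2ccccc2)nn1CCC(=S)N1CCCC1`, has not yet been measured in this assay. It differs from compound 2 in one place: a group of 7 heavy atoms (5 carbon, 1 nitrogen, 1 sulfur; one five-membered non-aromatic ring with 1 hetero atom) in place of a group of 3 heavy atoms (1 carbon, 1 nitrogen, 1 oxygen; no ring), on a saturated chain carbon, two bonds along the chain from an aromatic nitrogen. The group that enters carries a sulfur in place of the oxygen of the carbamoyl that leaves, and a five-membered ring in place of the free amide.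

Among the compounds with values here, one measured step bears on this change. The move from compound 2 to compound 3 also swapped the carbamoyl for a sulfur-bearing group on the chain, and it brought a number 89.2 percentage points higher from compound 2 to compound 3 (beyond the scatter). The same ring-bearing sulfur group as in compound 4 sits on a core without the phenyl in compound 1, and compound 1 gives 29.7%, a moderate number.

Within the data shown here, from this, the step to compound 4 is expected to be a large rise, a number 57.8 percentage points higher from compound 2 to compound 4 (beyond the scatter), though smaller than the one seen for compound 3. Compound 4 is therefore estimated at 55%, within a range of 20% to 90%.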

Compound 4, a percentage reported as inhibition, in the whole organism at one dose (the size of the read-out at that dose, not a potency): 38.2%
Compound 4: middle estimate off by 16.8 percentage points, on the high side; the measured number falls inside the stated range.
By their numbers in this assay, from the lowest: compound 2; then compounds 1 and 4 (each within the scatter of the next); then compound 3.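

In this assay, placing the sulfur-bearing group with its five-membered ring where the carbamoyl stood, on a saturated chain carbon, two bonds along the chain from an aromatic nitrogen, gives a number 41 percentage points higher from compound 2 to compound 4 (beyond the scatter). Within the data shown here, this is a second sulfur-bearing group at this place that lifts the number, whereas the earlier compounds offered only one such step. The phenyl in place of hydrogen on an aromatic carbon gives a number 8.5 percentage points higher from compound 1 to compound 4 (within the scatter), so with this ring-bearing group on the chain, the numbers with and without the phenyl cannot be told apart at this single dose. Nothing measured here explains why the swap on the chain matters so much in this whole-animal test.

It stays open whether the sulfur itself matters, since the same ring-bearing group with a carbonyl in place of the sulfur does not appear among these compounds. From the compounds shown here alone, how a carboxylic acid, an amine or a longer chain would read at this place also remains unknown, as does the result of removing the phenyl from a compound that keeps the carbamoyl.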